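The source may report more compounds than this note shows. Statements on the series, on what has been measured and on what is new or still open speak of the compounds shown alone.

Measured compounds:

Compound 1, `O=S(=O)(NCCNCc1ccc(-c2ccccc2)cc1)c1cc(C(F)(F)F)cc(C(F)(F)F)c1` — 2700 nM
Compound 2, `O=S(=O)(NCCCNCC1COc2ccccc2O1)c1cc(C(F)(F)F)cc(C(F)(F)F)c1` — 2600 nM
Compound 3, `O=S(=O)(NCCCCCCNCc1ccc(Br)cc1)c1ccc2ccsc2c1` — 6000 nM

All three were tested in a functional assay on MIA PaCa-2 cells (Homo sapiens) for inhibition, read by MTT assay, with a stated time of 72 h; a lower number here means a stronger inhibitor of growth, a higher number a weaker inhibitor of growth. Compound 2 has the lowest number of the three in this assay, yet its gap to compound 1 lies within the scatter, so the two cannot be ranked against each other; only compound 3, with its higher number, lies beyond the scatter from compound 2.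

Compound 4, `O=S(=O)(NCCCNCc1ccc(Cl)cc1)c1cc(C(F)(F)F)cc(C(F)(F)F)c1`, has not been measured. Compared with compound 2 it carries one change: 4-chlorophenyl in place of 2,3-dihydro-1,4-benzodioxin-2-yl on a saturated chain carbon bound to an amine nitrogen. Cut one bond further out, the change reads (2,3-dihydro-1,4-benzodioxin-2-yl)methyl to 4-chlorobenzyl; the rest of the molecule is unchanged.

Among the compounds with values here, no measured pair in this set isolates this change, so there is no step to lean on. The three numbers all sit close together even though the compounds differ in several places, which suggests that this end of the molecule tolerates variation. The expected step from compound 2 to compound 4 in this assay is therefore small, a 1.2-fold higher number from compound 2 to compound 4 (0.06 log units; within the scatter), not beyond the scatter. Compound 4 is estimated at 3000 nM, within a range from 1200 nM to 8000 nM.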

Compound 4, concentration for 50% growth inhibition: 2800 nM
Compound 4: the middle estimate sits 1.1-fold (0.03 log units) above what was measured, and the stated range covers the measured number.
By their numbers in this assay, from the lowest: compounds 2, 1 and 4 (each within the scatter of the next); then compound 3.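

Within the data shown here, replacing 2,3-dihydro-1,4-benzodioxin-2-yl with 4-chlorophenyl on a saturated chain carbon bound to an amine nitrogen gives, in this assay, a 1.1-fold higher number from compound 2 to compound 4 (0.03 log units; within the scatter), and this is the first comparison here between compounds that differ in one place only. The group that leaves has a non-aromatic ring and 2 hydrogen-bond acceptors, the group that enters has neither, and for this pair that difference does not register in growth inhibition. No measurement at hand speaks to what lies behind this result.

As far as these compounds go, what a carboxylic acid or an amine on the benzyl ring would do at this place stays open. So does the effect of chain length alone, since the compounds with other chains also differ elsewhere.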